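A few compounds are considered here, and "the series" means these few. Any claim that something is new, unique, unknown or untested is made for them only; others in the source may bear on it.

Measured so far in a functional assay on MCF7 cells (Homo sapiens) for antiproliferative activity; a higher number here means a weaker inhibitor, a lower number a stronger inhibitor:

compound 1 `Cc1ccc(-c2cn(-c3cc4ccc(O)c(C)c4oc3=O)nn2)cc1` — 23200 nM.
compound 2 `CO[C@@H]1[C@@H](O)[C@@H](O)[C@H](Oc2ccc3c(c2C)OC(=O)C(n2cc(-c4ccc(C)cc4)nn2)C3)OC1(C)C` — > 100000 nM.
compound 3 `Cc1c(O)ccc2cc(-n3cc(-c4ccc(F)cc4F)nn3)c(=O)oc12` — 33500 nM.

For compound 2 the value is a limit of the assay, not a number; it sits at the limit of > 100000 nM in this assay, at which 1 of the 3 values shown sits. Compound 1 and compound 2 share the triazole with its 4-methylphenyl, but the difference between the two cores is not broken down here.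

Among the measured compounds shown here, the one measured step, (2,4-difluorophenyl in place of 4-methylphenyl on an aromatic carbon), gives a 1.4-fold higher number from compound 1 to compound 3 (0.16 log units; within the scatter). The same change is now made on the core of compound 2, giving compound 4 `CO[C@@H]1[C@@H](O)[C@@H](O)[C@H](Oc2ccc3c(c2C)OC(=O)C(n2cc(-c4ccc(F)cc4F)nn2)C3)OC1(C)C`: 2,4-difluorophenyl in place of 4-methylphenyl on an aromatic carbon. The place lines of the two changes read alike.

For compound 4 the step that the limit leaves unreadable from compound 2 to compound 4 is expected, resting on the flat step of a 1.4-fold higher number from compound 1 to compound 3 (0.16 log units; within the scatter) and on compound 2 standing at the limit. Compound 4 is thus estimated at 130000 nM, between 40000 nM and 500000 nM, most likely again reported only as a limit.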

Compound 4, half-maximal inhibitory concentration: > 100000 nM
Compound 4: a limit, no number; the forecaster's own chance of this, stated with the estimate: 80%; the middle value does not contradict the limit.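

Compound 2 and compound 4 both stand only as limits, so no step between them can be read: the limit of > 100000 nM in this assay, at which 2 of the 4 values shown sit.

As far as these compounds go, whether 2,4-difluorophenyl in place of 4-methylphenyl shifts activity on the core of compound 2 stays open.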